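This account rests on a few compounds, and the source may have more. Where it says the series, first, only, none or still open, it means among the compounds named here.

Compound 1 `CN1CCC(C(=O)N2Cc3c(NC(=O)Nc4cccc(F)c4)n[nH]c3C2(C)C)CC1`: > 225000 nM
Compound 2 `CC(=O)N1CCC(C(=O)N2Cc3c(NC(=O)c4ccc(F)cc4)n[nH]c3C2(C)C)CC1`: 204000 nM

In a physicochemical assay for solubility, at pH 7 (a higher number here means a more soluble compound, a lower number a less soluble compound), compound 1 gives > 225000 nM, which is a limit of the assay and not a number (the limit of > 225000 nM in this assay, at which 1 of the 2 values shown sits). Compound 2 gives 204000 nM in this assay. Compound 3 `CN1CCC(C(=O)N2Cc3c(NC(=O)c4ccncc4)n[nH]c3C2(C)C)CC1` has not yet been measured in this assay. It differs from compound 1 in one place: pyridin-4-yl in place of (3-fluorophenyl)amino on a carbonyl carbon. For the measured compounds named here, no step between two measured compounds is available here, so the expectation rests on compound 1 alone. In this assay the expected step is a step that the limit leaves unreadable from compound 1 to compound 3, none beyond the scatter. Compound 3 is estimated at 250000 nM, within 150000 nM to 400000 nM, and is expected to come back most likely as a limit again.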

Compound 3, solubility: > 225000 nM
Compound 3 was reported as a limit (the forecaster's own chance of this, stated with the estimate: 70%); the middle value is on the limit's open side.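

In this assay compound 1 and compound 3 both come back as limits, so no step between them can be read: the limit of > 225000 nM in this assay, at which 2 of the 3 values shown sit.

The compounds shown leave open how far pyridin-4-yl in place of (3-fluorophenyl)amino on a carbonyl carbon moves this read-out, if at all.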